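Replacing an amide with its methylated inverse on the shared core

This account rests on a few compounds, and the source may have more. Where it says the series, first, only, none or still open, it means among the compounds named here.

Compound 1 `O=C(Nc1ccccc1)c1cnc(NCc2c(F)ccc3c2CCO3)n2cnnc12` was examined in a physicochemical assay for solubility, read by LC-MS, in phosphate buffer, with a stated time of 24 h, at pH 7.4; a lower number here means a less soluble compound, a higher number a more soluble compound. In this assay compound 1 gives only a limit, < 1000 nM, at the limit of < 1000 nM in this assay, at which 1 of the 3 values shown sits. Two compounds on a different core were also measured: compound 2 `Cn1cc(-c2cnc(NCc3c(F)ccc4c3CCO4)c3cn[nH]c(=O)c23)cn1` gives 1000 nM, and compound 3 `Cc1nc(CO)ccc1-c1cnc(NCc2c(F)ccc3c2CCO3)c2cn[nH]c(=O)c12` gives 3000 nM, a step of a 3.0-fold higher number from compound 2 to compound 3 (0.48 log units; beyond the scatter). That step changes another group on another core and does not bear on the change at hand. Compound 4 `CN(C(=O)c1ccccc1)c1cnc(NCc2c(F)ccc3c2CCO3)n2cnnc12` differs from compound 1 by benzoyl(methyl)amino in place of phenylcarbamoyl on an aromatic carbon. Among the measured compounds shown here, no measured step speaks to this swap, so its direction is open; compound 4 is expected to give 1000 nM (range 300 nM to 4000 nM), a step estimated as a number no lower from compound 1 to compound 4 (the limit leaves the size open), with a real chance that the assay again reports only a limit.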

Compound 4, solubility: 280000 nM
Compound 4: the middle estimate sits 280-fold (2.45 log units) below what was measured; measured number outside the range, above it.
By their numbers in this assay, from the lowest: compound 2; then compound 3; then compound 4.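

At this aromatic carbon of the shared core, the swap to benzoyl(methyl)amino gives, in this assay, an at least 280-fold higher number from compound 1 to compound 4 (2.44 log units; beyond the scatter), the first step read at this position and far larger than the one seen on the other core. Compound 1 stands at a limit of the assay, so the true size of the step stays open: the limit of < 1000 nM in this assay, at which 1 of the 4 values shown sits.

The compounds shown leave open whether the added methyl or the reversed amide carries the step, and with it the loss of the amide hydrogen; a benzoylamino group, without the methyl, would separate the two. They also leave open how a longer chain in place of that methyl would read.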